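Trifluoromethyl in place of bromo: from compound 3 to compound 4

A few compounds are considered here, and "the series" means these few. Any claim that something is new, unique, unknown or untested is made for them only; others in the source may bear on it.

In a functional assay on OCI-Ly3 cells (Homo sapiens) for inhibition, read by CellTiter-Glo, with stated times of 48 h and 96 h (a lower number here means a stronger inhibitor of growth, a higher number a weaker inhibitor of growth), compound 1 `CC(C)[C@@H](C(=O)N1CCC[C@H]1C(=O)N[C@@H](CCCNC(=N)N)C(=O)CF)N(C)C(=O)OCc1ccccc1` reaches only the limit of the assay, > 20000 nM. Compound 2 `CC(C)[C@H](NC(=O)c1ccccc1Br)C(=O)N1CCC[C@H]1C(=O)N[C@@H](CCCNC(=N)N)C(=O)CF` gives 4240 nM, and compound 3 `CC(C)[C@H](NC(=O)c1ccc(Br)cc1)C(=O)N1CCC[C@H]1C(=O)N[C@@H](CCCNC(=N)N)C(=O)CF` gives 130 nM, the lowest number among the three. The measured steps are an at least 4.7-fold lower number from compound 1 to compound 2 (0.67 log units; beyond the scatter), an at least 150-fold lower number from compound 1 to compound 3 (2.18 log units; beyond the scatter) and a 33-fold lower number from compound 2 to compound 3 (1.51 log units; beyond the scatter), so the group on the ring and where it sits decide the outcome here. Compound 4 `CC(C)[C@H](NC(=O)c1ccc(C(F)(F)F)cc1)C(=O)N1CCC[C@H]1C(=O)N[C@@H](CCCNC(=N)N)C(=O)CF` differs from compound 3 by trifluoromethyl in place of bromo on an aromatic carbon. Among the compounds with values here, no measured step exchanges one group for another at that place, so the expectation rests on compound 3 alone. The estimate for compound 4 is a step of a 1.5-fold higher number from compound 3 to compound 4 (0.19 log units; within the scatter), within the scatter, giving an expected 200 nM with a range of 60 nM to 700 nM.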

Compound 4, concentration for 50% growth inhibition: 120 nM
Compound 4: middle estimate off by 1.7-fold (0.22 log units), on the high side; the range from low to high includes it.
By their numbers in this assay, from the lowest: compounds 4 and 3 (each within the scatter of the next); then compound 2. At a limit, above all of these: compound 1.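

Exchanging bromo for trifluoromethyl on this aromatic carbon gives a 1.1-fold lower number from compound 3 to compound 4 (0.03 log units; within the scatter) and so leaves the two groups indistinguishable in this pair. Compound 2 remains far apart, with a 35-fold lower number from compound 2 to compound 4 (1.55 log units; beyond the scatter) for 4-(trifluoromethyl)phenyl in place of 2-bromophenyl, so the low number is now held by two different groups at this place rather than by bromo alone. Going by these compounds, whether an amine or a carboxylic acid on the same aromatic carbon would also keep the number this low remains open. Nothing measured for these compounds bears on why the two groups match.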